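Methyl addition on the pyrrole core of compound 2

The source may report more compounds than this note shows. Statements on the series, on what has been measured and on what is new or still open speak of the compounds shown alone.

Compound 2 `Cc1c[nH]cc1C(=O)O` gives the highest number of the two measured compounds: in an assay on cells for inhibition of Palmitoleoyl-protein carboxylesterase NOTUM variant C330S (Homo sapiens), read by fluorescence, with a stated time of 40 min (a lower number here means a stronger inhibitor, a higher number a weaker inhibitor), compound 2 gives 100000 nM. Compound 1 `Cc1cc(C(=O)O)c(C)n1CC1CC1` gives 12700 nM in this assay, a gap beyond the scatter. Compound 3 `Cc1c[nH]c(C)c1C(=O)O` differs from compound 2 by methyl in place of hydrogen on an aromatic carbon. Compound 1 carries the same methyl together with further substituents, so a step toward a lower number is expected, but a modest one, since the gap to compound 1 need not be closed by this change alone. Compound 3 is therefore estimated at 45000 nM, within 15000 nM to 120000 nM, the expected step being a 2.2-fold lower number from compound 2 to compound 3 (0.35 log units; beyond the scatter).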

Compound 3, half-maximal inhibitory concentration: 100000 nM
The estimate for compound 3 lay 2.2-fold (0.35 log units) below the measured number; the measured number falls inside the stated range.
By their numbers in this assay, from the lowest: compound 1; then compounds 2 and 3 (each within the scatter of the next).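

In this assay, methyl in place of hydrogen on an aromatic carbon gives no change at the digits printed from compound 2 to compound 3 (within the scatter). This position, next to the ring nitrogen and next to the ring atom that bears a carboxy group, therefore shows no response to a single methyl. No supporting data bear on this result.

As far as these compounds go, whether a longer chain, such as ethyl, or an amine at this position would change the number remains open. Going by these compounds alone, equally open is what a cyclopropylmethyl group on the ring nitrogen would do as the only change to compound 2.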